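Swapping Ethyl for Phenyl: What Cytotoxicity to Expect

This account rests on a few compounds, and the source may have more. Where it says the series, first, only, none or still open, it means among the compounds named here.

Measured so far:
Compound 1 `CCNC(=S)Nc1cccc(C(F)(F)F)c1`: > 100000 nM
Compound 2 `FC(F)(F)c1cccc(NC(=S)Nc2ccc(I)cc2)c1`: 10000 nM
Compound 3 `CCOC(=O)c1ccc(NC(=S)Nc2cccc(C(F)(F)F)c2)cc1`: 23000 nM

In an ADME assay on MT4 cells (Homo sapiens) for cytotoxicity (a lower number here means that less compound is tolerated, a higher number that more compound is tolerated), compound 1 gives > 100000 nM. That value is a limit of the assay and not a measured number. Compound 1 stands at the limit of > 100000 nM in this assay, at which 1 of the 3 values shown sits. Compound 2 gives 10000 nM in this assay, and compound 3 gives 23000 nM.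

Compound 4, `FC(F)(F)c1cccc(NC(=S)Nc2ccccc2)c1`, has not yet been measured. It differs from compound 1 by phenyl in place of ethyl on an amide-type nitrogen. The step that bears most directly on this change is an at least 10-fold lower number from compound 1 to compound 2 (1.00 log units; beyond the scatter), where 4-iodophenyl, rather than plain phenyl, replaced ethyl on the same nitrogen. The step of a 2.3-fold higher number from compound 2 to compound 3 (0.36 log units; beyond the scatter) shows that exchanging the group on the aromatic carbon of that ring moved the number only modestly. The change from compound 1 to compound 4 is therefore expected to lower the number beyond the scatter, estimated as an at least 4.0-fold lower number from compound 1 to compound 4 (0.60 log units; beyond the scatter). Compound 4 is expected to give 25000 nM, estimated to lie between 8000 nM and 100000 nM.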

Compound 4, half-maximal cytotoxic concentration: 39000 nM
Beside the measured number, compound 4's estimate is 1.6-fold (0.19 log units) below it, and the stated range covers the measured number.
By their numbers in this assay, from the lowest: compound 2; then compounds 3 and 4 (each within the scatter of the next). At a limit, above all of these: compound 1.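

In this assay, plain phenyl on the amide-type nitrogen still lowers the number (an at least 2.5-fold lower number from compound 1 to compound 4 (0.40 log units; beyond the scatter)), so the earlier drop with 4-iodophenyl did not depend on the iodo alone. The group on the aromatic carbon also counts, though unevenly: hydrogen in place of iodo gives a 3.9-fold higher number from compound 2 to compound 4 (0.59 log units; beyond the scatter) and so accounts for part of that drop, while hydrogen in place of ethoxycarbonyl gives a 1.7-fold higher number from compound 3 to compound 4 (0.23 log units; within the scatter) and stays within the scatter. The full size of the change from ethyl to phenyl stays unknown, since compound 1 carries a limit and not a number: the limit of > 100000 nM in this assay, at which 1 of the 4 values shown sits.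

On these data alone, it remains open whether a carboxylic acid or an amine on that aromatic carbon would differ from hydrogen beyond the scatter. Also open, as far as these compounds go, is where a longer chain such as butyl, or a benzyl group, on the nitrogen would fall relative to ethyl and phenyl.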